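This account rests on a few compounds, and the source may have more. Where it says the series, first, only, none or still open, it means among the compounds named here.

Three compounds with the same ring-opened thiazolidinedione arm are compared in a functional assay on MDA-MB-231 cells (Homo sapiens) for inhibition, read by MTT assay, with a stated time of 48 h (on this read-out lower numbers stand for stronger inhibition and higher numbers for weaker inhibition), and a fourth waits to be measured. Compound 3 `COc1cc2c(cc1OC)CN(C(=O)CN1C(=O)S/C(=C\c3nc4ccccc4n3C(C)C)C1=O)CC2` carries an isopropyl group on the benzimidazole nitrogen of its core; in this assay compound 3 gives 30600 nM. Compound 1 `CCn1c(/C=C2\SC(=O)N(CC(=O)N3CCc4cc(OC)c(OC)cc4C3)C2=O)nc2ccccc21` differs from it by hydrogen in place of methyl on a saturated chain carbon bound to an aromatic nitrogen and a saturated chain carbon. In this assay compound 1 reaches only a limit, > 50000 nM. The step from compound 3 to compound 1 therefore reads an at least 1.6-fold higher number from compound 3 to compound 1 (0.21 log units; that floor lies within the scatter), and its floor rests on (the limit of > 50000 nM in this assay, at which 2 of the 3 values shown sit).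

Compound 2 `CCn1c(/C=C2\SC(=O)N(CC(=O)N3CC(C)OC(C)C3)C2=O)nc2ccccc21` has a different amide partner; how its core differs from the core of compound 3 is not broken down here. In this assay compound 2 also gives only a limit, > 50000 nM. Compound 4 `CC1CN(C(=O)CN2C(=O)S/C(=C\c3nc4ccccc4n3C)C2=O)CC(C)O1` differs from compound 2 by hydrogen in place of methyl on a saturated chain carbon bound to an aromatic nitrogen. Within the data shown here, this is the same kind of change as the one from compound 3 to compound 1, but not the same: there the place was a saturated chain carbon bound to an aromatic nitrogen and a saturated chain carbon, here only a saturated chain carbon bound to an aromatic nitrogen.

For compound 4 a step that the limit leaves unreadable from compound 2 to compound 4 is expected, which rests on the earlier step from compound 3 to compound 1 an at least 1.6-fold higher number from compound 3 to compound 1 (0.21 log units; that floor lies within the scatter) and on the limit at the limit of > 50000 nM in this assay, at which 2 of the 3 values shown sit. Compound 4 is thus estimated at 90000 nM in this assay, most likely again only a limit, with the true value expected between 40000 nM and 250000 nM.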

Compound 4, half-maximal inhibitory concentration: > 50000 nM
Compound 4 was reported as a limit; the forecaster's own chance of this, stated with the estimate: 85%; the middle value is on the limit's open side.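

In this assay compound 4 gives only a limit (> 50000 nM). Among these compounds, no step between compound 2 and compound 4 can be read, because compound 2 also stands at a limit and neither compound has a number: (the limit of > 50000 nM in this assay, at which 3 of the 4 values shown sit). The compounds shown leave open what the true values of compound 2 and compound 4 are, and whether going from ethyl to methyl changes anything in this pair.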